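Chloro for fluoro on a sulfonamide cinnamamide series

The source may report more compounds than this note shows. Statements on the series, on what has been measured and on what is new or still open speak of the compounds shown alone.

Three N-sulfonyl cinnamamides have been tested in a functional assay on B16-F10 cells (Mus musculus) for antiproliferative activity, read by ELISA and MTT assay, with a stated time of 48 h; a lower number here means a stronger inhibitor, a higher number a weaker inhibitor. Compound 1 `O=C(/C=C/c1ccc(F)cc1)NS(=O)(=O)c1ccccc1` gives 2.1 ug/mL. Compound 2 `O=C(/C=C/c1ccc(F)cc1)NS(=O)(=O)c1ccc(F)cc1` gives 0.8 ug/mL, and compound 3 `O=C(/C=C/c1ccc(F)cc1)NS(=O)(=O)c1ccc(Cl)cc1` gives 2.6 ug/mL. The change from compound 1 to compound 2 brought a 2.6-fold lower number from compound 1 to compound 2 (0.42 log units; beyond the scatter), while that from compound 1 to compound 3 brought a 1.2-fold higher number from compound 1 to compound 3 (0.09 log units; within the scatter).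

Compound 4 `O=C(/C=C/c1ccc(Cl)cc1)NS(=O)(=O)c1ccccc1` is not yet measured in this assay. It differs from compound 1 by chloro in place of fluoro on an aromatic carbon. The same change, (chloro in place of fluoro on an aromatic carbon), is seen between compound 2 and compound 3, where it gave a 3.3-fold higher number from compound 2 to compound 3 (0.51 log units; beyond the scatter). The core of compound 1 differs from that of compound 2 by hydrogen in place of fluoro on an aromatic carbon.

Resting on the step from compound 2 to compound 3, a 3.3-fold higher number from compound 2 to compound 3 (0.51 log units; beyond the scatter), compound 4 is expected to show a higher number than compound 1, a step of about a 1.7-fold higher number from compound 1 to compound 4 (0.22 log units; within the scatter). Going by the values given here, the single precedent sits on a different core, so the estimate is loose. Compound 4 is expected to give about 3.5 ug/mL, with a range from 1.5 ug/mL to 8 ug/mL.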

Compound 4, half-maximal inhibitory concentration: 2.2 ug/mL
Compound 4: middle estimate off by 1.6-fold (0.20 log units), on the high side; the measured number falls inside the stated range.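

In this assay, putting chloro in place of fluoro on the core of compound 1 gave a 1.0-fold higher number from compound 1 to compound 4 (0.02 log units; within the scatter), so this pair shows no measurable effect of the swap, unlike the pair on the core of compound 2. Going by these compounds alone, the step therefore did not carry over in size from one core to the other: the same change on two cores in this assay, a 3.3-fold higher number (0.51 log units; beyond the scatter) from compound 2 to compound 3 and a 1.0-fold higher number (0.02 log units; within the scatter) from compound 1 to compound 4, 3.1-fold (0.49 log units) apart, beyond the scatter of two such steps This shows that the step seen on one core could not be relied on for the other, but with only one pair per core, and the swap falling on a different aromatic ring in each pair, it does not show whether the ring carrying the swap or the rest of the core sets the outcome.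

The compounds shown carry only hydrogen, fluoro or chloro on their aromatic rings, so how bromo, methyl, methoxy or nitrile groups would behave in this assay remains open. Also open, as far as these compounds go, is what a methyl group in place of the amide hydrogen would do on either core.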